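The source may hold more compounds than are shown below. What is called first, only, known or untested is meant among the compounds shown, and "the series" means these compounds.

For the measured compounds named here, compound 1 `O=C(CSc1nc2cccnc2[nH]1)Nc1cccc(Br)c1` stands highest of the two numbers so far in an assay on isolated protein for inhibition of Ectonucleotide pyrophosphatase/phosphodiesterase family member 1 (Homo sapiens), tested at 10 uM (on this read-out lower numbers stand for less inhibition and higher numbers for more inhibition at the one concentration tested (going by the name of the read-out)), where compound 1 gives 23%. Its nearest neighbour is compound 2 `O=C(CSc1nc2cccnc2[nH]1)Nc1ccccc1F`, which in this assay gives 13%. Going by the values given here, the one measured step, a number 10 percentage points lower from compound 1 to compound 2 (within the scatter), goes with 2-fluorophenyl in place of 2-bromophenyl's relative, 3-bromophenyl, on an amide-type nitrogen, and it stays within the scatter.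

Compound 3 `N#Cc1cccc(NC(=O)CSc2nc3cccnc3[nH]2)c1` has not yet been measured in this assay. Compared with compound 1 it shows (cyano in place of bromo on an aromatic carbon), that is, cyano in place of bromo on an aromatic carbon of a six-membered aromatic ring of carbon only, meta to a large group. The step from compound 1 to compound 2 is the only one that touches the same phenyl ring, and it exchanged both the halogen and its place at once, so it bears on the present change only loosely; since it was within the scatter, nothing beyond the scatter is expected here either. Compound 3 is therefore estimated at 18%, with a range from 4% to 34%, an expected step of a number 5 percentage points lower from compound 1 to compound 3 (within the scatter).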

Compound 3, a percentage reported as inhibition, at one concentration (the size of the read-out at that concentration, not a potency): 45%
For compound 3 the middle estimate is 27 percentage points below the measured one; the measured number lies above the stated range.
By their numbers in this assay, from the lowest: compounds 2 and 1 (each within the scatter of the next); then compound 3.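

Replacing bromo with cyano at this place on the phenyl ring reads in this assay as a number 22 percentage points higher from compound 1 to compound 3 (beyond the scatter) and is the only step shown so far that lies beyond the scatter. The step from compound 1 to compound 2 changed the halogen and its place together, whereas this one keeps the place fixed, meta to a large group, and shows that the group at this position alone can move the read-out. The change replaces one heavy atom with two and adds a triple bond and a hydrogen-bond acceptor, but no measurement bears on which of these features goes with the higher number or why.

From the compounds shown here alone, it remains open whether the higher number is particular to the nitrile or would also appear with another group at this place, such as an amine, a carboxylic acid or a methoxy group. It is also open whether cyano would give a similar number elsewhere on the ring, as compound 3 is the only compound shown that carries it.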